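Series notes: benzoxaborole amides, cytotoxicity on fibroblasts

The compounds below may be only part of what the source reports. "The series", "measured", "known", "first", "only" and "open" are said of these compounds alone.

Measured so far:
compound 1 `O=C(CCc1cccc2c1B(O)OC2)Nc1ccc(F)cc1` — 12000 nM
compound 2 `O=C(CCc1cccc2c1B(O)OC2)Nc1cccc(Br)c1` — 20000 nM
compound 3 `Cc1ccc(NC(=O)CCc2cccc3c2B(O)OC3)cc1Br` — 15000 nM

All three share one core and differ only in the aryl group on the amide nitrogen. In an ADME assay on WI-38 cells (Homo sapiens) for cytotoxicity, read by MTT assay, with a stated time of 72 h (a lower number here means a stronger inhibitor, a higher number a weaker inhibitor), compound 1 gives 12000 nM, compound 2 gives 20000 nM and compound 3 gives 15000 nM. Compound 2 carries the largest number of the three, but the step of a 1.7-fold higher number from compound 1 to compound 2 (0.22 log units; within the scatter) and the step of a 1.3-fold lower number from compound 2 to compound 3 (0.12 log units; within the scatter) both lie within the scatter, so the three compounds cannot be told apart in this assay.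

Compound 4 `O=C(CCc1cccc2c1B(O)OC2)Nc1cccc(-c2ccc(C(F)(F)F)cc2)c1` has not yet been measured. It differs from compound 2 in one place: 4-(trifluoromethyl)phenyl in place of bromo on an aromatic carbon. Among the compounds with values here, no measured step touches this change; the two steps on record swap one small halogen-bearing aryl for another or add a methyl, and neither moved the number beyond the scatter. The series therefore gives no ground to expect a step beyond the scatter for the step from compound 2 to compound 4, and the estimated step is a 1.7-fold lower number from compound 2 to compound 4 (0.22 log units; within the scatter). Compound 4 is expected to give about 12000 nM in this assay, with a range from 5000 nM to 30000 nM.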

Compound 4, half-maximal inhibitory concentration: 26000 nM
Estimate against measurement, compound 4: 2.2-fold (0.34 log units) below; the range from low to high includes it.
By their numbers in this assay, from the lowest: compounds 1, 3, 2 and 4 (each within the scatter of the next, the first and the last beyond it).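

In this assay, 4-(trifluoromethyl)phenyl in place of bromo gives a 1.3-fold higher number from compound 2 to compound 4 (0.11 log units; within the scatter), so going from 1 heavy atom to 10 heavy atoms, with one six-membered aromatic ring added, does not separate compound 4 from compound 2. The earlier steps shown here covered only an exchange of aryl groups on the amide nitrogen and the addition of a methyl; this step shows that a far larger group on this aromatic carbon, meta to a large group, still leaves the number within the scatter. Nothing on record offers an explanation for this result.

The compounds shown leave open whether an amine or a carboxylic acid at this position would move the number beyond the scatter. They also leave open whether a longer chain between the shared core and the amide would do so.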